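The source may report more compounds than this note shows. Statements on the series, on what has been measured and on what is new or still open speak of the compounds shown alone.

Measured so far: compound 1 `Cc1nc2c(-c3ccc(Cl)cc3Cl)ccnc2n(C(C)C(C)C)c1=O` gives 380 nM, compound 2 `CCC(C1CC1)n1c(=O)c(C)nc2c(-c3cc(C)c(C)c(C)c3C)ccnc21` gives 340 nM, and compound 3 `CC[C@H](C1CC1)n1c(=O)c(C)nc2c(-c3cc(C)c(OC)nc3C)ccnc21` gives 15 nM in a functional assay for antagonist activity at corticotropin-releasing factor receptor 1 (Rattus norvegicus); on this read-out lower numbers stand for stronger inhibition and higher numbers for weaker inhibition.

Compound 1 stands at the highest of the three numbers; compound 2 sits within the scatter of it, while compound 3 lies well beyond it at a lower number. Compound 4 `CC[C@@H](C1CC1)n1c(=O)c(C)nc2c(-c3ccc(Cl)cc3Cl)ccnc21` has not been measured. It differs from compound 1 in one place: 1-cyclopropylpropyl in place of 1,2-dimethylpropyl on an aromatic nitrogen. For the measured compounds named here, compound 2 and compound 3 both carry the entering group, but their other parts differ too, so no single step isolates it. Compound 4 is expected to show a modest step to a lower number, a 2.5-fold lower number from compound 1 to compound 4 (0.40 log units; beyond the scatter). The value of compound 4 in this assay is estimated at 150 nM, within 40 nM to 600 nM.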

Compound 4, half-maximal inhibitory concentration: 7.4 nM
Beside the measured number, compound 4's estimate is 20-fold (1.31 log units) above it; measured number outside the range, below it.
By their numbers in this assay, from the lowest: compound 4; then compound 3; then compounds 2 and 1 (each within the scatter of the next).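

With the dichlorophenyl part held constant, the exchange of 1,2-dimethylpropyl for 1-cyclopropylpropyl on the aromatic nitrogen gives, in this assay, a 51-fold lower number from compound 1 to compound 4 (1.71 log units; beyond the scatter). For the compounds shown here, this is the first single change isolated, and it shows that the group on this nitrogen can by itself move the read-out by a large margin. No available measurement accounts for the size of this step.

Going by these compounds, whether a dicyclopropylmethyl or 1-cyclobutylpropyl group on this nitrogen would give a lower or higher number remains open. Also unresolved is how the opposite stereocentre of 1-cyclopropylpropyl would compare.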